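The source may report more compounds than this note shows. Statements on the series, on what has been measured and on what is new or still open speak of the compounds shown alone.

Of the compounds shown here, three that share one core have been tested in an ADME assay on MDBK cells (Bos taurus) for cytotoxicity; a higher number here means that more compound is tolerated, a lower number that less compound is tolerated. Compound 1 `Cc1ccn(Cc2c(F)cccc2F)c2nc(-c3c(F)cccc3F)nc1-2` is reported there as > 100000 nM, which is a limit of the assay rather than a number. Compound 2 `Clc1ccccc1Cn1ccc2nc(-c3ccccc3)nc-2c1` likewise stands at a limit, > 100000 nM, so its standing is known only as that boundary. Compound 3 `FC(F)(F)c1ccc(Cn2ccc3nc(-c4ccccc4)nc-3c2)cc1` gives a number, 84000 nM, while the limit of > 100000 nM in this assay, at which 2 of the 3 values shown sit, marks where the other two values rest. Compound 4 `CC(C)N(CCn1ccc2nc(-c3ccccc3)nc-2c1)C(C)C`, not yet measured, differs from compound 2 in one place: (diisopropylamino)methyl in place of 2-chlorophenyl on a saturated chain carbon bound to an aromatic nitrogen. Among the measured compounds shown here, no step between measured compounds exists to gauge this change, so the step that is expected, a number no higher from compound 2 to compound 4 (the limit leaves the size open), is none beyond the usual scatter. Compound 4 is accordingly expected to give about 100000 nM, within 30000 nM to 300000 nM, most likely again reported only as a limit.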

Compound 4, half-maximal cytotoxic concentration: > 100000 nM
Compound 4: a limit, no number; the forecaster's own chance of this, stated with the estimate: 60%; the middle value sits exactly at the limit.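

Compound 2 and compound 4 are both reported only as limits in this assay, so no step can be read between them. The compounds shown leave open whether (diisopropylamino)methyl in place of 2-chlorophenyl changes how much compound is tolerated, and by how much.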